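The compounds below may be only part of what the source reports. "The series", "measured", "known", "first", "only" and "open" are said of these compounds alone.

Compound 1 `CC#C[C@H]1CN(S(=O)(=O)c2ccc(N)nc2)CCN1c1ccc([C@@](O)(CO)C(F)(F)F)cc1` stands lowest of the two numbers measured in an ADME assay (liver) for metabolic stability, with Liver microsome (Rattus norvegicus) as the target, using microsomes and NADPH, with a stated time of 30 min (on this read-out lower numbers stand for slow clearance and higher numbers for fast clearance), where compound 1 gives 53 mL.min-1.g-1. Compound 2 `CC#C[C@H]1CN(S(=O)(=O)c2ccc(N)nc2)CCN1c1ccc(C(O)(CC#N)C(F)(F)F)cc1` gives 57 mL.min-1.g-1, and the step of a 1.1-fold higher number from compound 1 to compound 2 (0.03 log units; within the scatter). Compound 3 `CC#C[C@H]1CN(S(=O)(=O)c2ccc(N)nc2)CCN1c1ccc(S(=N)(=O)C2CC2)cc1` differs from compound 1 in one place: a group of 6 heavy atoms (3 carbon, 1 nitrogen, 1 oxygen, 1 sulfur; one three-membered non-aromatic ring of carbon only) in place of a group of 8 heavy atoms (3 carbon, 2 oxygen, 3 fluorine; no ring), on an aromatic carbon. Going by the values given here, the single measured step, from compound 1 to compound 2, exchanged one group without a ring for another of similar kind, so it bears only loosely on a change that brings in a three-membered ring and sulfur. With that step within the scatter, no shift beyond the scatter is expected, so compound 3 is estimated at 45 mL.min-1.g-1, between 18 mL.min-1.g-1 and 110 mL.min-1.g-1, a step of a 1.2-fold lower number from compound 1 to compound 3 (0.07 log units; within the scatter).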

Compound 3, intrinsic clearance in microsomes: 23 mL.min-1.g-1
Compound 3: middle estimate off by 2.0-fold (0.29 log units), on the high side, within the range that was stated.
By their numbers in this assay, from the lowest: compound 3; then compounds 1 and 2 (each within the scatter of the next).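

In this assay, the group on this aromatic carbon, para to a large group, can shift the number: the earlier exchange left it within the scatter, whereas the sulfur-containing group with its three-membered ring gives a 2.3-fold lower number from compound 1 to compound 3 (0.36 log units; beyond the scatter) and a 2.5-fold lower number from compound 2 to compound 3 (0.39 log units; beyond the scatter). These steps are modest, and since the whole group changes at once, the roles of the sulfur, the ring and the loss of the fluorines cannot be separated. Nothing available here bears on the reason for these steps. From the compounds shown here alone, it remains open whether a cyclopropyl sulfone or a simple amine at this place would give a number as low as compound 3 does.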